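Swapping the bromophenyl for a dihydroxyphenyl in a urea series

A few compounds are considered here, and "the series" means these few. Any claim that something is new, unique, unknown or untested is made for them only; others in the source may bear on it.

Compound 1 `CN(C)CCn1cnnc1-c1cc(Oc2ccc(NC(=O)N/N=C/c3cccc(Br)c3)cc2F)ccn1` is tested in a functional assay on MKN-45 cells (Homo sapiens) for cytotoxicity, read by MTT assay, with a stated time of 72 h (on this read-out lower numbers stand for stronger inhibition and higher numbers for weaker inhibition), where compound 1 gives 450 nM, the lowest of the three numbers measured. Compound 2 `COc1ccc(/C=N/NC(=O)Nc2ccc(Oc3ccnc(-c4nncn4CCN(C)C)c3)c(F)c2)cc1O` gives 2510 nM, and compound 3 `CN(C)CCn1cnnc1-c1cc(Oc2ccc(NC(=O)N/N=C/c3ccc(F)cc3F)cc2F)ccn1` gives 810 nM. Among the compounds with values here, the only change from compound 1 to compound 4 `CN(C)CCn1cnnc1-c1cc(Oc2ccc(NC(=O)N/N=C/c3ccc(O)cc3O)cc2F)ccn1` is 2,4-dihydroxyphenyl in place of 3-bromophenyl on a carbon with a double bond to nitrogen. The step that most resembles this one is a 5.6-fold higher number from compound 1 to compound 2 (0.75 log units; beyond the scatter), where a hydroxyl-bearing ring also replaced the 3-bromophenyl; the step of a 1.8-fold higher number from compound 1 to compound 3 (0.26 log units; within the scatter) shows that a ring with two fluorines leaves the number nearly unchanged. With two hydroxyls entering, a weakening of roughly the size seen for compound 2 is expected, so a 4.0-fold higher number from compound 1 to compound 4 (0.60 log units; beyond the scatter) is the estimated step. Compound 4 is therefore expected to give about 1800 nM, within a range from 700 nM to 5000 nM.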

Compound 4, half-maximal inhibitory concentration: 2860 nM
For compound 4 the middle estimate is 1.6-fold (0.20 log units) below the measured one; the range from low to high includes it.
By their numbers in this assay, from the lowest: compounds 1 and 3 (each within the scatter of the next); then compounds 2 and 4 (each within the scatter of the next).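

The 2,4-dihydroxyphenyl ring gives a 6.4-fold higher number from compound 1 to compound 4 (0.80 log units; beyond the scatter) in this assay. Compounds 3 and 4 differ only in carrying fluorines or hydroxyls on an otherwise matching ring, and that exchange alone gives a 3.5-fold higher number from compound 3 to compound 4 (0.55 log units; beyond the scatter), so the substituents matter here and not just the loss of the 3-bromophenyl. The two hydroxyl-bearing rings also stay level, with a 1.1-fold higher number from compound 2 to compound 4 (0.06 log units; within the scatter).

Nothing given here explains why the hydroxyl-bearing rings give higher numbers. On these data alone, whether a 2,4-diaminophenyl ring, carrying amines instead, would sit with the hydroxyl-bearing rings or with compound 3 stays open.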